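A third heteroaryl amide, tested for growth inhibition

The source may report more compounds than this note shows. Statements on the series, on what has been measured and on what is new or still open speak of the compounds shown alone.

- Compound 1 `CCCCCCCCCCCC[C@@H](O)[C@H]1CC[C@H]([C@H](O)CCCCCCCCCCNC(=O)c2ccoc2)O1`: 100000 nM
- Compound 2 `CCCCCCCCCCCC[C@@H](O)[C@H]1CC[C@H]([C@H](O)CCCCCCCCCCNC(=O)c2ccsc2)O1`: 100000 nM

Compound 2 gives 100000 nM in a functional assay on SF-268 cells (Homo sapiens) for inhibition, read by colorimetric assay and sulforhodamine B assay, with a stated time of 48 h (on this read-out lower numbers stand for stronger inhibition of growth and higher numbers for weaker inhibition of growth), level with compound 1. Compound 3 `CCCCCCCCCCCC[C@@H](O)[C@H]1CC[C@H]([C@H](O)CCCCCCCCCCNC(=O)c2ccnn2C)O1` carries 1-methyl-1H-pyrazol-5-yl in place of thiophen-3-yl on a carbonyl carbon. For the measured compounds named here, only one measured step bears on this change, no change at the digits printed from compound 1 to compound 2 (within the scatter), which also swaps one five-membered aromatic ring for another at that place. A single step is a thin guide, but it gives no reason to expect a change beyond the scatter in this assay. The expected step is a 1.1-fold lower number from compound 2 to compound 3 (0.05 log units; within the scatter). For compound 3 the estimated value is 90000 nM, with an expected range of 40000 nM to 100000 nM.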

Compound 3, concentration for 50% growth inhibition: 100000 nM
Beside the measured number, compound 3's estimate is 1.1-fold (0.05 log units) below it; low and high end bracket the measured number.
By their numbers in this assay, from the lowest: compounds 1, 2 and 3 (each within the scatter of the next).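

Both no change at the digits printed from compound 2 to compound 3 (within the scatter) and no change at the digits printed from compound 1 to compound 3 (within the scatter) hold in this assay once 1-methyl-1H-pyrazol-5-yl sits on the carbonyl carbon. The earlier pair covered only a swap between rings with 1 hetero atom, whereas this position now also shows the same printed number with a ring of 2 hetero atoms and 6 heavy atoms. No evidence is available to explain this result. From the compounds shown here alone, whether an aminomethyl or carboxylic acid substituent on this ring would move the number remains open. So does whether a shorter chain between the amide nitrogen and the shared core would.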